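Working notes: from compound 3 to compound 4

The source may hold more compounds than are shown below. What is called first, only, known or untested is meant among the compounds shown, and "the series" means these compounds.

Of the compounds shown here, three on the shared core have been measured in a functional assay on K562 cells (Homo sapiens) for cytotoxicity, read by MTT assay; on this read-out lower numbers stand for stronger inhibition and higher numbers for weaker inhibition. Compound 1 `COc1ccc(/C=C/C(=O)c2ccc(OC)c3c2OC(C)(C)C=C3)cc1OCCCN(C)C` gives 2920 nM, compound 2 `CCCCC(=O)Oc1cc(/C=C/C(=O)c2ccc(OC)c3c2OC(C)(C)C=C3)ccc1OC` gives 240 nM and compound 3 `COc1ccc(/C=C/C(=O)c2ccc(OC)c3c2OC(C)(C)C=C3)cc1OC(=O)c1ccco1` gives 450 nM. Compound 3 stands close to compound 2, with a 1.9-fold higher number from compound 2 to compound 3 (0.27 log units; within the scatter), and far from compound 1, with a 6.5-fold lower number from compound 1 to compound 3 (0.81 log units; beyond the scatter).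

The next compound is compound 4 `COc1ccc(/C=C/C(=O)c2ccc(OC)c3c2OC(C)(C)C=C3)cc1CS(C)(=O)=O`. The change is (methylsulfonyl)methyl in place of ((furan-2-yl)carbonyl)oxy on an aromatic carbon, ortho to a methoxy group.

The measured steps bear on this only indirectly. Two of them replace 3-(dimethylamino)propyl on the oxygen with a carbonyl-linked group: a 12-fold lower number from compound 1 to compound 2 (1.09 log units; beyond the scatter) and a 6.5-fold lower number from compound 1 to compound 3 (0.81 log units; beyond the scatter). These steps show that this substituent can move the number well beyond the scatter, whereas exchanging one acyl chain for another gave only a 1.9-fold higher number from compound 2 to compound 3 (0.27 log units; within the scatter). Within the data shown here, no measured compound has a sulfonyl group or lacks that oxygen. Compound 4 does share with compound 1, at 2920 nM, the absence of a carbonyl-linked oxygen, so a rise is expected, though short of that value. The expected change is a 2.2-fold higher number from compound 3 to compound 4 (0.35 log units; beyond the scatter), a moderate and uncertain step. For compound 4 the estimated value is 1000 nM, with an expected range of 300 nM to 3500 nM.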

Compound 4, half-maximal inhibitory concentration: 9240 nM
The estimate for compound 4 lay 9.2-fold (0.97 log units) below the measured number; the whole stated range lies below it.
By their numbers in this assay, from the lowest: compounds 2 and 3 (each within the scatter of the next); then compound 1; then compound 4.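

In this assay, among these compounds, putting (methylsulfonyl)methyl on this aromatic carbon, ortho to a methoxy group, gives a 21-fold higher number from compound 3 to compound 4 (1.31 log units; beyond the scatter) and, against the butyl ester, a 39-fold higher number from compound 2 to compound 4 (1.59 log units; beyond the scatter) on the same change; both steps exceed any step among the earlier compounds. The same group also gives a 3.2-fold higher number from compound 1 to compound 4 (0.50 log units; beyond the scatter) in place of 3-(dimethylamino)propoxy, so compound 1 no longer marks the weak end of the set, and compound 4 is the weakest of the four in this assay, with all three of its steps beyond the scatter. No measurement at hand accounts for the size of these steps.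

This change removes the oxygen link and the acyl group together, so the compounds shown do not separate the contribution of the linking atom from that of the group it carries. From the compounds shown here alone, a free hydroxyl, a plain methoxy, or a methylsulfonyl group attached directly to the ring at this carbon would help to separate them, and the effect of a sulfonamide here remains open as well.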